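The source may report more compounds than this note shows. Statements on the series, on what has been measured and on what is new or still open speak of the compounds shown alone.

Series values in an assay on mitochondria from L6 cells (Rattus norvegicus) for activation, with a stated time of 90 min; a higher number here means that more compound is needed for the effect, a lower number that less compound is needed:

compound 1 `Fc1cccc(Nc2nc3nonc3nc2Nc2ccccc2F)c1`: 190 nM
compound 2 `Oc1nc2nonc2nc1Nc1ccc(S(F)(F)(F)(F)F)cc1`: 3900 nM
compound 3 `Cc1cc(C)c(Nc2nc3nonc3nc2O)c(C)c1`: 113000 nM

Compound 2 stands second highest of the three numbers. Its nearest neighbour is compound 1, whose number is lower by a margin beyond the scatter; compound 3 lies further away, with a number higher than that of compound 2 by a margin also beyond the scatter. Among the measured compounds shown here, no single-change step between measured compounds is known in this set, so the step to compound 4 `CCCCCCc1ccc(Nc2nc3nonc3nc2O)cc1` has no measured precedent.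

Compound 4 differs from compound 2 in one place: a group of 6 heavy atoms (6 carbon; no ring) in place of a group of 6 heavy atoms (5 fluorine, 1 sulfur; no ring), on an aromatic carbon. The change sits on an aromatic carbon of a six-membered aromatic ring of carbon only, para to a large group.

For the measured compounds named here, with no comparable step known, the expectation for this assay rests on compound 2 alone. An upward step of modest size, likely beyond the scatter, is expected from compound 2 to compound 4, a 2.1-fold higher number from compound 2 to compound 4 (0.31 log units; beyond the scatter). For compound 4 the estimate is 8000 nM, with a range from 2000 nM to 32000 nM.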

Compound 4, half-maximal effective concentration: 4700 nM
The estimate for compound 4 lay 1.7-fold (0.23 log units) above the measured number; measured number inside the range.
By their numbers in this assay, from the lowest: compound 1; then compounds 2 and 4 (each within the scatter of the next); then compound 3.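

In this assay, among the compounds shown here, the first single-change step reads a 1.2-fold higher number from compound 2 to compound 4 (0.08 log units; within the scatter), so on this aromatic carbon, para to a large group, hexyl stands in place of the group of 5 fluorine and 1 sulfur with no change beyond the scatter. The two groups match in what is counted for them, with 6 heavy atoms, no ring and no hydrogen-bond donors or acceptors, yet share no atom type, and in this one pair that difference in atoms does not separate the two numbers. Nothing measured here accounts for this result.

A single step cannot show whether a butyl chain, a longer chain, an amine or a carboxylic acid at this place would also stay within the scatter of compound 2. It also leaves open whether hexyl would read the same way on the core of compound 1.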